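Amide nitrogen substitution in the shared core, compound 3 to 4

The source may report more compounds than this note shows. Statements on the series, on what has been measured and on what is new or still open speak of the compounds shown alone.

Measured in an assay on isolated protein for inhibition of Fatty-acid amide hydrolase 1 (Homo sapiens), read by fluorescence, with a stated time of 30 min; on this read-out lower numbers stand for stronger inhibition and higher numbers for weaker inhibition:
- compound 1 `CCOC(=O)c1cc(-c2cccc(OC(=O)NC3CCCCC3)c2)n(-c2ccc(C)cc2)n1`: 29 nM
- compound 2 `NC(=O)c1cc(-c2cccc(OC(=O)NC3CCCCC3)c2)n(-c2ccccc2)n1`: 169 nM
- compound 3 `CC(C)NC(=O)c1cc(-c2cccc(OC(=O)NC3CCCCC3)c2)n(-c2ccccc2)n1`: 232 nM

Compound 3 gives the highest of the three numbers in this assay. Its nearest neighbour is compound 2, and the step of a 1.4-fold higher number from compound 2 to compound 3 (0.14 log units; within the scatter) lies within the scatter. Compound 1 is the furthest away; it differs from compound 3 in more than one place, so the two values are only compared as they stand, with compound 1 giving 29 nM against compound 3 at 232 nM.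

Compound 4 `CCN(CC)C(=O)c1cc(-c2cccc(OC(=O)NC3CCCCC3)c2)n(-c2ccccc2)n1` carries the change (diethylamino in place of isopropylamino on a carbonyl carbon). Among the measured compounds shown here, the only measured step at this position is a 1.4-fold higher number from compound 2 to compound 3 (0.14 log units; within the scatter), which stayed within the scatter when the amide hydrogen gave way to isopropyl. For the measured compounds named here, that step is the sole guide; no measured pair covers a disubstituted amide nitrogen. The expectation is therefore a step of no more than the scatter in this assay for compound 4, in either direction, with a slightly wider range to allow for the untested change, estimated as a 1.1-fold higher number from compound 3 to compound 4 (0.05 log units; within the scatter).

For compound 4 the value in this assay is estimated at 260 nM, with a range from 100 nM to 700 nM.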

Compound 4, half-maximal inhibitory concentration: 448 nM
The estimate for compound 4 lay 1.7-fold (0.24 log units) below the measured number; the measured number falls inside the stated range.
By their numbers in this assay, from the lowest: compound 1; then compounds 2, 3 and 4 (each within the scatter of the next, the first and the last beyond it).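

In this assay, diethylamino in place of isopropylamino on the carbonyl carbon gives a 1.9-fold higher number from compound 3 to compound 4 (0.29 log units; within the scatter), so this change taken alone stays inside the scatter. Read against the unsubstituted amide, however, the position does show a difference: diethylamino in place of amino gives a 2.7-fold higher number from compound 2 to compound 4 (0.42 log units; beyond the scatter), a modest step toward weaker inhibition and the first amide step in the series beyond the scatter. Compound 4 also brings a group on the carbonyl carbon that counts no hydrogen-bond donor, against one for isopropylamino, but nothing available ties the step to that count or to any other feature.

The compounds shown do not separate the loss of the amide hydrogen from the change in the carbon substituents, and a methylamino or dimethylamino group on the same carbonyl carbon would bear on that question. Going by these compounds, how a carboxylic acid or a longer chain such as n-butylamino would read at this place also remains open, as does any direct comparison with the ethyl ester of compound 1, which differs from these amides in more than one place.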